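The source may hold more compounds than are shown below. What is called first, only, known or untested is meant among the compounds shown, and "the series" means these compounds.

In an ADME assay on BaF3 cells (Mus musculus) for antiproliferative activity, read by CCK-8 assay, with a stated time of 72 h (on this read-out higher numbers stand for weaker inhibition of growth and lower numbers for stronger inhibition of growth), compound 1 `O=C(CCSc1ccc2c(/C=C/c3ccccn3)n[nH]c2c1)Nc1cccc(Cl)c1` gives 9350 nM and compound 2 `O=C(CCSc1ccc2c(/C=C/c3ccccn3)n[nH]c2c1)Nc1cccc(C(F)(F)F)c1` gives 2300 nM. Compound 3 `Cc1ccc(NC(=O)CCSc2ccc3c(/C=C/c4ccccn4)n[nH]c3c2)cc1` gives > 10000 nM. That value is a limit of the assay and not a number.

The change now in view leads to compound 4 `O=C(CCSc1ccc2c(/C=C/c3ccccn3)n[nH]c2c1)Nc1ccc(F)c(C(F)(F)F)c1`: 4-fluoro-3-(trifluoromethyl)phenyl in place of 4-methylphenyl on an amide-type nitrogen. In words, 4-fluoro-3-(trifluoromethyl)phenyl replaces 4-methylphenyl on the amide-type nitrogen.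

Within the data shown here, two measured steps bear on this change. The swap of the aryl group on the same nitrogen gave an at least 4.3-fold higher number from compound 2 to compound 3 (0.63 log units; beyond the scatter), and trifluoromethyl in place of chloro gave a 4.1-fold lower number from compound 1 to compound 2 (0.61 log units; beyond the scatter). By contrast, an at least 1.0-fold higher number from compound 1 to compound 3 (0.02 log units; that floor lies within the scatter) separates nothing. Among the measured compounds shown here, no measured step covers the added fluoro.

Compound 4 keeps the trifluoromethyl of compound 2, so a number near the 2300 nM of compound 2 is expected, with a wide margin for the fluoro. The expected step is an at least 4.5-fold lower number from compound 3 to compound 4 (0.65 log units; beyond the scatter), a modest or larger move towards stronger inhibition of growth in this assay. For compound 4 the estimated value is 2200 nM, with an expected range from 600 nM to 8000 nM.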

Compound 4, concentration for 50% growth inhibition: 610 nM
Compound 4: the middle estimate sits 3.6-fold (0.56 log units) above what was measured; the measured number falls inside the stated range.
By their numbers in this assay, from the lowest: compound 4; then compound 2; then compound 1. At a limit, above all of these: compound 3.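

On the aryl group at the amide-type nitrogen, fluoro in place of hydrogen on an aromatic carbon gives a 3.8-fold lower number from compound 2 to compound 4 (0.58 log units; beyond the scatter) in this assay, so a further substituent on the trifluoromethyl-bearing ring still moves the number beyond the scatter. Against 3-chlorophenyl, the 4-fluoro-3-(trifluoromethyl)phenyl group gives a 15-fold lower number from compound 1 to compound 4 (1.19 log units; beyond the scatter), and in these compounds trifluoromethyl in place of chloro and the added fluoro both run towards stronger inhibition of growth. Against 4-methylphenyl, the change gives an at least 16-fold lower number from compound 3 to compound 4 (1.21 log units; beyond the scatter), a floor resting on a limit for compound 3 and not on a number: the limit of > 10000 nM in this assay, at which 1 of the 4 values shown sits.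

On these data alone, whether the fluoro step holds with chloro in place of trifluoromethyl remains open. Also open, as far as these compounds go, is how an amine or a carboxylic acid on this aryl group, or a longer chain in its place, would read in this assay.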